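The source may report more compounds than this note shows. Statements on the series, on what has been measured and on what is new or still open speak of the compounds shown alone.

Measured so far in a physicochemical assay for solubility, with a stated time of 18 h, at pH 7.4; on this read-out lower numbers stand for lower solubility and higher numbers for higher solubility:
- compound 1 `CC(C)Cc1ccc2c(NCCCNCc3ccco3)ccnc2c1`: 4200 nM
- compound 2 `c1ccc(CCc2ccc3c(NCCCNCc4ccco4)ccnc3c2)cc1`: 4200 nM
- compound 3 `CC(C)CCc1ccc2c(NCCCNCc3ccco3)ccnc2c1`: 4200 nM

The three share one core and differ only in the group on the saturated chain carbon bound to an aromatic carbon. On the numbers in hand compound 3 stands level with compounds 1 and 2: the steps of no change at the digits printed from compound 1 to compound 2 (within the scatter), no change at the digits printed from compound 1 to compound 3 (within the scatter) and no change at the digits printed from compound 2 to compound 3 (within the scatter) are all flat, so nothing in this assay separates the three.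

Compound 4 `c1coc(CNCCCNc2ccnc3cc(CC4CCCCC4)ccc23)c1` is not yet measured in this assay. Against compound 3 the change is cyclohexyl in place of isobutyl on a saturated chain carbon bound to an aromatic carbon.

Within the data shown here, the steps that bear on it are those at the same place: no change at the digits printed from compound 1 to compound 3 (within the scatter) and no change at the digits printed from compound 1 to compound 2 (within the scatter), each a change of the group at the saturated chain carbon bound to an aromatic carbon, and each without movement beyond the scatter. A six-membered non-aromatic ring of carbon only has not been tried here, so the new group goes beyond the measured set, but with three flat steps the expectation is no change beyond the scatter, in either direction.

For compound 4 the estimate in this assay is 4000 nM, with a range of 2000 nM to 8400 nM. The expected step from compound 3 is a 1.1-fold lower number from compound 3 to compound 4 (0.02 log units; within the scatter).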

Compound 4, solubility: 4200 nM
Beside the measured number, compound 4's estimate is 1.1-fold (0.02 log units) below it; measured number inside the range.
By their numbers in this assay, from the lowest: compounds 1, 2, 3 and 4 (each within the scatter of the next).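

In this assay a six-membered non-aromatic ring of carbon only, at the saturated chain carbon bound to an aromatic carbon, leaves the read-out flat, with no change at the digits printed from compound 3 to compound 4 (within the scatter) and no change at the digits printed from compound 2 to compound 4 (within the scatter) and likewise no change at the digits printed from compound 1 to compound 4 (within the scatter) for the same swap from isopropyl. The place now tolerates isopropyl, isobutyl, benzyl and cyclohexyl without separation, so the flat picture holds across compounds 1, 2, 3 and 4, with none of them going against it, and it now extends to a saturated ring as well as to open chains and a phenyl-bearing group. No measurement offers an explanation for this flatness.

Isobutyl and cyclohexyl both count 0 hydrogen-bond donors and 0 hydrogen-bond acceptors, so whether a group carrying them at this place, such as a primary amine, a hydroxyl or a carboxylic acid, would move the number remains open. Also open, on these data alone, is whether a change elsewhere on the shared core would separate compounds that this place does not.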